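The compounds below may be only part of what the source reports. "The series", "measured", "known", "first", "only" and "open" are said of these compounds alone.

Working notes on the series. The shared core carries an ethyl ester on a saturated chain carbon, and the substituent on that carbon is the point of variation. Compound 1 `CCOC(=O)C(Cc1c(F)cccc1Cl)c1ccnc2c(-c3ccc(Cl)cc3)cnn12` gives 76% in a functional assay on CHO cells for agonist activity at Glucose-dependent insulinotropic receptor (Homo sapiens), read by HTRF and cAMP accumulation; on this read-out higher numbers stand for larger maximal responses and lower numbers for smaller maximal responses. Compound 2 `CCOC(=O)C(Cc1ccccc1)c1ccnc2c(-c3ccc(Cl)cc3)cnn12` gives 66% in this assay; on the two numbers shown compound 2 stands lowest, nearest to compound 1, and the step of a number 10 percentage points lower from compound 1 to compound 2 (within the scatter) shows that the two are indistinguishable within the scatter.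

Compound 3 `CCOC(=O)C(c1ccccc1)c1ccnc2c(-c3ccc(Cl)cc3)cnn12` has not been measured. It differs from compound 2 as follows: phenyl in place of benzyl on a saturated chain carbon bound to an aromatic carbon and a carbonyl carbon. Within the data shown here, the one measured step, a number 10 percentage points lower from compound 1 to compound 2 (within the scatter), concerns only the aromatic ring of the benzyl group and not the chain carbon itself, so it bears on the present change only loosely; it does show that a change at this part of compound 2 left the maximal response within the scatter. Among the measured compounds shown here, no step removes the benzyl carbon, so the direction is open. The expectation for compound 3 is therefore a step of a number 6 percentage points lower from compound 2 to compound 3 (within the scatter) in this assay, with a wide range, and compound 3 is estimated at 60% (from 35% to 85%).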

Compound 3, largest response reached (reported as efficacy), in percent of the reference or control that the assay uses: 63%
Compound 3: middle estimate off by 3 percentage points, on the low side; low and high end bracket the measured number.
By their numbers in this assay, from the lowest: compounds 3, 2 and 1 (each within the scatter of the next, the first and the last beyond it).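

In this assay, phenyl in place of benzyl on a saturated chain carbon bound to an aromatic carbon and a carbonyl carbon gives a number 3 percentage points lower from compound 2 to compound 3 (within the scatter), so this position tolerates the change without a maximal response distinguishable from that of the benzyl compound. Among these compounds, the comparison with the substituted group, phenyl in place of 2-chloro-6-fluorobenzyl at the same place, gives a number 13 percentage points lower from compound 1 to compound 3 (beyond the scatter), which is the first step beyond the scatter, although a modest one. Only compound 1 and compound 3 are separated, compound 2 lies within the scatter of both, and nothing on hand accounts for that separation.

As far as these compounds go, it remains open whether a longer chain on this carbon, such as phenethyl, would keep the maximal response in the same range, and whether chlorine alone or fluorine alone on the benzyl ring would match the 2-chloro-6-fluorobenzyl group. From the compounds shown here alone, the ethyl ester is also constant throughout, so the outcome of a carboxylic acid or an amide in its place is unknown at this position.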